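Swapping the pyridine for a thiazole on the lactam ring

The compounds below may be only part of what the source reports. "The series", "measured", "known", "first", "only" and "open" are said of these compounds alone.

The shared core of compound 1 `CC1CN(C(=O)Nc2cc(F)c(F)c(F)c2)Cc2c(N3CC(C#N)CC3=O)cnn21`, compound 2 `O=C1CC(c2ccc(F)cn2)CN1c1cnn2c1CN(C(=O)Nc1cc(F)c(F)c(F)c1)C(C1CC1)C2` and compound 3 `O=C1CC(Oc2ncccn2)CN1c1cnn2c1CN(C(=O)Nc1cc(F)c(F)c(F)c1)C(C1CC1)C2` was tested in a toxicity assay on HepG2 2.2.15 cells (Homo sapiens) for cytotoxicity, read by CellTiter-Glo; a lower number here means that less compound is tolerated, a higher number that more compound is tolerated. Compound 1 gives 115000 nM there. Compound 2 gives 38500 nM, the lowest of the two numbers in this assay. For compound 3 the assay reports only a limit, > 200000 nM, which is a limit of the measurement and not a number (the limit of > 200000 nM in this assay, at which 1 of the 3 values shown sits). Among the measured compounds shown here, the one step that bears on the present question is an at least 5.1-fold higher number from compound 2 to compound 3 (0.71 log units; beyond the scatter), so a change on the saturated ring carbon of the five-membered lactam has moved the read-out in this assay before.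

Compound 4 `O=C1CC(c2nccs2)CN1c1cnn2c1CN(C(=O)Nc1cc(F)c(F)c(F)c1)C(C1CC1)C2` differs from compound 2 in the same place: 1,3-thiazol-2-yl in place of 5-fluoropyridin-2-yl on a saturated ring carbon. Because compound 3 showed an at least 5.1-fold higher number from compound 2 to compound 3 (0.71 log units; beyond the scatter) when the group on that carbon was exchanged, the step of a 1.8-fold higher number from compound 2 to compound 4 (0.26 log units; within the scatter) is expected to run in the same upward direction but by less, since the number may stay below the limit. Compound 4 is therefore estimated at 70000 nM, within 25000 nM to 200000 nM, in this assay.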

Compound 4, half-maximal cytotoxic concentration: 115000 nM
Estimate against measurement, compound 4: 1.6-fold (0.22 log units) below, within the range that was stated.
By their numbers in this assay, from the lowest: compound 2; then compounds 1 and 4 (each within the scatter of the next). At a limit, above all of these: compound 3.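

In this assay, among the compounds shown here, the new step shows that the upward move from compound 2 on this saturated ring carbon does not depend on an oxy link such as the one in compound 3: 1,3-thiazol-2-yl, which has none, also gives a 3.0-fold higher number from compound 2 to compound 4 (0.48 log units; beyond the scatter). Against the other replacement, the data give only an at least 1.7-fold lower number from compound 3 to compound 4 (0.24 log units; that floor lies within the scatter), so how far compound 4 and compound 3 really lie apart remains unresolved. Compound 3 stands at a limit and not at a number: the limit of > 200000 nM in this assay, at which 1 of the 4 values shown sits.

The compounds shown leave open whether the move from compound 2 follows from losing the fluorine of the 5-fluoropyridin-2-yl group, which an unsubstituted pyridin-2-yl group would test. They also leave open how a non-aromatic group on this carbon, such as an amine or a carboxylic acid, would read out in this assay.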